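This account rests on a few compounds, and the source may have more. Where it says the series, first, only, none or still open, it means among the compounds named here.

For the measured compounds named here, compound 1 `C#Cc1ccccc1N/N=N/c1ccc(C(=N)N)cc1` has the highest number of the two compounds measured so far in a functional assay on MDA-MB-231 cells (Homo sapiens) for antiproliferative activity, read by WST assay, with a stated time of 72 h (on this read-out lower numbers stand for stronger inhibition of growth and higher numbers for weaker inhibition of growth), giving 23200 nM. Its nearest neighbour, compound 2 `N=C(N)c1ccc(/N=N/Nc2cccc(C#Cc3ccccc3)c2)cc1`, gives 9500 nM in this assay, a number that lies beyond the usual scatter below that of compound 1. Going by the values given here, no step between two measured compounds that differ in a single place has been recorded, so the comparison of compound 1 with compound 2 shows only what the two values themselves show.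

Compound 3 `N=C(N)c1ccc(/N=N/Nc2ccccc2C#Cc2ccc(F)cc2)cc1` is the not yet measured compound of interest. It is derived from compound 1 by a single change, (4-fluorophenyl in place of hydrogen on a triple-bonded carbon); cut one bond further out, the same difference reads ethynyl to 2-(4-fluorophenyl)ethynyl. Compound 2, which also carries a phenyl on its triple-bonded carbon, gives a lower number than compound 1 in this assay, though it is not a one-place step from either compound.

On that basis compound 3 is expected to give a moderately lower number than compound 1, a step of a 2.1-fold lower number from compound 1 to compound 3 (0.32 log units; beyond the scatter) that lies beyond the scatter. The estimate for compound 3 in this assay is 11000 nM, with a range from 4000 nM to 30000 nM.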

Compound 3, concentration for 50% growth inhibition: 6200 nM
Compound 3: the middle estimate sits 1.8-fold (0.25 log units) above what was measured; low and high end bracket the measured number.
By their numbers in this assay, from the lowest: compounds 3 and 2 (each within the scatter of the next); then compound 1.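

In this assay, for the compounds shown here, putting 4-fluorophenyl in place of hydrogen on a triple-bonded carbon gives a 3.7-fold lower number from compound 1 to compound 3 (0.57 log units; beyond the scatter), the first step in this set in which only one place changes. It shows that this position accepts a group of 7 heavy atoms carrying a six-membered aromatic ring, and that growth inhibition does not weaken but strengthens, by a modest step that lies beyond the usual scatter. No measurement is at hand that would account for this change in the number.

On these data alone, it remains open how much of the step belongs to the ring and how much to its fluorine, as compound 2 carries a phenyl on its triple-bonded carbon but is not a one-place step from compound 1 or compound 3, and so cannot settle the matter. Also open, as far as these compounds go, is how the same triple-bonded carbon would respond to a group of another kind, such as an amine, a carboxylic acid or a longer alkyl chain.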